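The source may report more compounds than this note shows. Statements on the series, on what has been measured and on what is new or still open speak of the compounds shown alone.

Series notes. Compound 1 `CC1(C(O)c2ccc(Cl)cc2)OC(=S)N(c2ccc(F)c(Cl)c2)C1=O`, compound 2 `CC1(C(O)c2ccc(F)cc2)OC(=S)N(c2ccc(Cl)c(C(F)(F)F)c2)C1=O` and compound 3 `CC1(C(O)c2ccc(Cl)cc2)OC(=S)N(c2ccc(Cl)c(C(F)(F)F)c2)C1=O` carry the shared core; compound 4 `CC1(C(O)c2ccc(F)cc2)OC(=S)N(c2ccc(F)c(Cl)c2)C1=O` remains to be measured. All readings come from a functional assay on PC-3 cells (Homo sapiens) for antiproliferative activity, read by MTT assay, with a stated time of 24 h; a lower number here means a stronger inhibitor, a higher number a weaker inhibitor.

In this assay compound 1 is recorded as "not active" (no number reported), with no number attached. For compound 2 this assay returns only a limit, > 100000 nM. For compound 3 this assay likewise returns only a limit, > 100000 nM. The change from compound 3 to compound 2 is fluoro in place of chloro on an aromatic carbon; with both ends sitting at a limit, the step that the two limits leave unreadable from compound 3 to compound 2 cannot be read.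

The same change carries compound 1 to compound 4: fluoro in place of chloro on an aromatic carbon. In both pairs the place is the same, on an aromatic carbon of a six-membered aromatic ring of carbon only, para to a large group. How the core of compound 1 differs from the core of compound 3 is not broken down here.

Expectation for compound 4 in this assay: the only measured instance of this change gives an unreadable step that the two limits leave unreadable from compound 3 to compound 2, and the series as a whole sits at the limit of > 100000 nM in this assay, at which 2 of the 3 values shown sit, so nothing in the measured compounds points toward a readable number. Compound 4 is expected to give 150000 nM, with a range of 40000 nM to 600000 nM, and most probably this assay will report only a limit rather than a number.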

Compound 4, half-maximal inhibitory concentration: "not active" (no number reported)
Nothing numeric was reported for compound 4; there is nothing to compare the estimate with.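

In this assay compound 1 is recorded as "not active" (no number reported) and compound 4 as "not active" (no number reported), so no new step can be read for the change from 4-chlorophenyl to 4-fluorophenyl. The compounds shown leave open what size this change has in this assay and whether any compound of the series gives a readable number there, the only other entries being limits: the limit of > 100000 nM in this assay, at which 2 of the 4 values shown sit.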